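Pentan-3-yl for dicyclopropylmethyl on the amine of compound 1

The compounds below may be only part of what the source reports. "The series", "measured", "known", "first", "only" and "open" are said of these compounds alone.

Measured so far in an in vitro ADME assay on microsomes (Rattus norvegicus) for metabolic stability; a higher number here means that the compound lasts longer, a lower number that the compound disappears faster:
- compound 1 `CCc1nc(-c2ccc(Cl)cc2Cl)c(CC)nc1NC(C1CC1)C1CC1`: 0.0417 h
- compound 2 `CCc1nc(-c2ccc(OC(F)(F)F)cc2OC)c(OC)nc1NC(CC)CC`: 0.6 h
- compound 3 `CCc1nc(-c2ccc(OC)cc2C(F)(F)F)c(CC)nc1NC(CC)CC`: 0.0717 h

Compound 1 gives the lowest of the three half-lives. Compound 3 sits within the scatter of compound 1, so the two cannot be ordered; compound 2 lies well beyond the scatter above compound 1.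

The next compound, compound 4 `CCc1nc(-c2ccc(Cl)cc2Cl)c(CC)nc1NC(CC)CC`, keeps the core and the aryl group of compound 1 and changes only the substituent on the amine nitrogen: pentan-3-yl in place of dicyclopropylmethyl on a nitrogen on an aromatic ring. Going by the values given here, compound 2 and compound 3 already carry pentan-3-yl, but each differs from compound 1 in its aryl substituents as well, so no pair of measured compounds isolates this change. The two half-lives that go with pentan-3-yl are 0.6 h for compound 2 and 0.0717 h for compound 3, and they span a wide interval between them.

With only that to go on, no step beyond the scatter is expected for this assay from compound 1 to compound 4; the expected step is a 1.4-fold higher number from compound 1 to compound 4 (0.16 log units; within the scatter). For compound 4 the half-life is estimated at 0.06 h, with a range from 0.025 h to 0.15 h.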

Compound 4, half-life: 0.07 h
For compound 4 the middle estimate is 1.2-fold (0.07 log units) below the measured one; the range from low to high includes it.
By their numbers in this assay, from the lowest: compounds 1, 4 and 3 (each within the scatter of the next); then compound 2.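

In this assay, the replacement of dicyclopropylmethyl by pentan-3-yl on a nitrogen on an aromatic ring can now be read on its own, with the core and aryl group of compound 1 held constant: the step is a 1.7-fold higher number from compound 1 to compound 4 (0.22 log units; within the scatter), so the two groups cannot be ordered here. With this aryl group in place, the loss of both three-membered rings and the change from the larger to the smaller substituent therefore give no step beyond the scatter, and compound 4 (0.07 h) and compound 1 (0.0417 h) remain indistinguishable in this read-out. Nothing available bears on why these two groups read alike.

Going by these compounds alone, whether the same replacement stays within the scatter with a different aryl group on the shared core remains open, since this is the only pair that isolates it. Also open, from the compounds shown here alone, is whether a substituent of another kind on this nitrogen, such as a chain carrying a hydroxyl group, a morpholine or a shorter branched chain such as isopropyl, would give a half-life clearly apart from those of compound 1 and compound 4.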